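A few compounds are considered here, and "the series" means these few. Any claim that something is new, unique, unknown or untested is made for them only; others in the source may bear on it.

Among the compounds with values here, compound 1 `OC[C@H]1O[C@@H](n2cnc3c(NCc4cccc(F)c4)ncnc32)[C@H](O)[C@@H]1O` is the only member of this set that returns a number in a functional assay on K562 cells (Homo sapiens) for antiproliferative activity, with a stated time of 72 h; a lower number here means a stronger inhibitor, a higher number a weaker inhibitor: compound 1 gives 7600 nM. Compound 2 `COc1ccc(CNc2ncnc3c2ncn3[C@@H]2O[C@H](CO)[C@@H](O)[C@H]2O)c(OC)c1` reaches the limit of the assay, > 166000 nM, which is not a number. Compound 3 `COc1cc(CNc2ncnc3c2ncn3[C@@H]2O[C@H](CO)[C@@H](O)[C@H]2O)cc(OC)c1` likewise sits at a limit, > 166000 nM. Both steps away from compound 1 are large: an at least 21-fold higher number from compound 1 to compound 2 (1.33 log units; beyond the scatter) and an at least 21-fold higher number from compound 1 to compound 3 (1.33 log units; beyond the scatter). The third step is a step that the two limits leave unreadable from compound 2 to compound 3, because the limit of > 166000 nM in this assay, at which 2 of the 3 values shown sit, holds both of its ends. Taken together, the two readable steps show that exchanging the whole fluorophenyl for a dimethoxyphenyl costs a great deal of activity.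

Compound 4 `OC[C@H]1O[C@@H](n2cnc3c(NCc4ccc(F)c(Cl)c4)ncnc32)[C@H](O)[C@@H]1O` differs from compound 1 as follows: 3-chloro-4-fluorophenyl in place of 3-fluorophenyl on a saturated chain carbon bound to a nitrogen on an aromatic ring. Within the data shown here, no measured step exchanges one halogenated phenyl for another; the measured steps show only that the group on the saturated chain carbon matters. With the fluorine kept and a chlorine added, the expected change is a 1.3-fold lower number from compound 1 to compound 4 (0.10 log units; within the scatter), which stays within the scatter. Compound 4 is therefore estimated at 6000 nM, with a range from 2000 nM to 20000 nM.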

Compound 4, half-maximal inhibitory concentration: 5500 nM
For compound 4 the middle estimate is 1.1-fold (0.04 log units) above the measured one, and the stated range covers the measured number.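

Compound 4 shows that this place on the saturated chain carbon accepts a second halogen on the phenyl ring without a readable change: a 1.4-fold lower number from compound 1 to compound 4 (0.14 log units; within the scatter). The gap to the dimethoxyphenyl compounds also holds for a second halogenated phenyl, not for the 3-fluorophenyl of compound 1 alone, with an at least 30-fold lower number from compound 3 to compound 4 (1.47 log units; beyond the scatter) and an at least 30-fold lower number from compound 2 to compound 4 (1.47 log units; beyond the scatter). Both of these large steps are bounds and not exact sizes, because compound 2 and compound 3 each stand at a limit: the limit of > 166000 nM in this assay, at which 2 of the 4 values shown sit.

As far as these compounds go, how a plain unsubstituted phenyl or a phenyl with a single methoxy group would read at this place remains open, so neither the need for halogen nor the cost of one methoxy group can be judged. Also open, from the compounds shown here alone, is how a phenyl carrying an amine or a carboxylic acid would read here.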